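A few compounds are considered here, and "the series" means these few. Any claim that something is new, unique, unknown or untested is made for them only; others in the source may bear on it.

The measured compounds, all built on the same core and differing only in the group on a sulfonyl sulfur:

Compound 1, `COc1ccc(S(=O)(=O)NC(=O)NC/C=C2\CCCc3cnn(Cc4ccc(Cl)cc4Cl)c32)cc1`: 29 nM in a functional assay on CHO-K1 cells for antagonist activity at prostaglandin E2 receptor EP3 subtype (Homo sapiens), read by TR-FRET and cAMP accumulation, with a stated time of 30 min; on this read-out higher numbers stand for weaker inhibition and lower numbers for stronger inhibition
Compound 2, `Cc1nc(C)c(S(=O)(=O)NC(=O)NC/C=C2\CCCc3cnn(Cc4ccc(Cl)cc4Cl)c32)s1`: 4 nM in this assay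
Compound 3, `O=C(NC/C=C1\CCCc2cnn(Cc3ccc(Cl)cc3Cl)c21)NS(=O)(=O)c1cc(Cl)c(Cl)s1`: 11 nM in this assay

Compound 3 holds the second highest of the three numbers. Its nearest neighbour is compound 1, as a 2.6-fold lower number from compound 1 to compound 3 (0.42 log units; beyond the scatter) shows, while compound 2 sits furthest from it, as seen in a 2.8-fold higher number from compound 2 to compound 3 (0.44 log units; beyond the scatter). The untested compound 4, `COc1ccccc1S(=O)(=O)NC(=O)NC/C=C1\CCCc2cnn(Cc3ccc(Cl)cc3Cl)c21`, differs from compound 3 in one place:

2-methoxyphenyl in place of 4,5-dichlorothiophen-2-yl on a sulfonyl sulfur

For the measured compounds named here, the step that speaks to this change is a 2.6-fold lower number from compound 1 to compound 3 (0.42 log units; beyond the scatter), since compound 1 also carries a methoxyphenyl group on the same sulfonyl sulfur; compound 4 differs from compound 1 only in where the methoxy sits, and no measured step separates those two. Reversing the move from compound 1 to compound 3 suggests a modest rise in the number for compound 4, beyond the scatter but not large. Compound 4 is therefore expected to show a 2.3-fold higher number from compound 3 to compound 4 (0.36 log units; beyond the scatter). Compound 4 is estimated at 25 nM, with a likely range from 8 nM to 80 nM.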

Compound 4, half-maximal inhibitory concentration: 114 nM
The estimate for compound 4 lay 4.6-fold (0.66 log units) below the measured number; the whole stated range lies below it.
By their numbers in this assay, from the lowest: compound 2; then compound 3; then compound 1; then compound 4.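

Where the methoxy sits on the phenyl ring turns out to matter, something no earlier pair could show: a 3.9-fold higher number from compound 1 to compound 4 (0.59 log units; beyond the scatter) is what separates 4-methoxyphenyl from 2-methoxyphenyl on this sulfonyl sulfur, so the two cannot be treated as the same group. The gaps to the other two groups are wider, with a 10-fold higher number from compound 3 to compound 4 (1.02 log units; beyond the scatter) on replacing 4,5-dichlorothiophen-2-yl and a 29-fold higher number from compound 2 to compound 4 (1.45 log units; beyond the scatter) on replacing 2,4-dimethyl-1,3-thiazol-5-yl, both large steps. As all three steps lie beyond the scatter, compound 4 is the weakest of the four in this assay and widens the spread that this one position produces while the rest of the molecule stays fixed.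

Nothing shown here gives a measured property that could explain this order of the four groups. Also open, on these data alone, is how a plain phenyl, or a phenyl carrying an amine or a carboxylic acid, would fare on the same sulfonyl sulfur, and whether the loss seen with 2-methoxyphenyl would recur with other groups at that spot on the ring.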